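A few compounds are considered here, and "the series" means these few. Any claim that something is new, unique, unknown or untested is made for them only; others in the source may bear on it.

Compound 1 `CC(=O)c1cccc(Nc2nc(-c3sc(NC(=O)NCc4ccc(Cl)cc4)nc3C)cs2)c1` enters this account without a result: in an ADME assay on RD cells (Homo sapiens) for cytotoxicity, read by microscopy (on this read-out lower numbers stand for higher toxicity in this test and higher numbers for lower toxicity in this test), compound 1 gives "not determined" (no result reported), so its place on the measured scale is open. Two neighbours sharing the acetylphenyl amine and the acylated aminothiazole do carry numbers. In this assay compound 2 `CC(=O)c1cccc(Nc2nc(-c3sc(NC(=O)C(F)(F)F)nc3C)cs2)c1` gives 30100 nM, and in this assay compound 3 `CC(=O)Nc1nc(C)c(-c2c[nH]c(Nc3cccc(C(C)=O)c3)n2)s1` gives 64200 nM; these two values lie within the usual scatter of one another and tell of weak cytotoxicity for this chemotype.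

Compound 4 `CCC(=O)Nc1nc(C)c(-c2csc(Nc3cccc(C(C)=O)c3)n2)s1` is reached from compound 1 by the change (ethyl in place of (4-chlorobenzyl)amino on a carbonyl carbon), that is, ethyl in place of (4-chlorobenzyl)amino on a carbonyl carbon. Among the compounds with values here, no measured pair shows this change, so the size of the step in this assay cannot be read off; he expects no movement beyond the scatter, with compound 4 landing near its acylated relatives.

He estimates for compound 4 in this assay a value of 40000 nM, expected to fall between 15000 nM and 100000 nM, because compound 2 gives 30100 nM and compound 3 gives 64200 nM.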

Compound 4, half-maximal cytotoxic concentration: 6370 nM
Compound 4: middle estimate off by 6.3-fold (0.80 log units), on the high side; measured number outside the range, below it.
By their numbers in this assay, from the lowest: compound 4; then compound 2; then compound 3.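

In this assay, the group on a carbonyl carbon whose other neighbour is an amide-type nitrogen proves able to move the read-out: ethyl in place of trifluoromethyl gives a 4.7-fold lower number from compound 2 to compound 4 (0.67 log units; beyond the scatter), a shift toward higher toxicity in this test. The earlier compounds shown here could not show this, as no two of those with numbers differed in one place only, and the step from compound 1 to compound 4 still cannot be read, since compound 1 has no number. Nothing at hand gives a reason for the size or direction of this step.

Going by these compounds, it remains open whether a longer chain such as butyl, a cyclopropyl ring or a phenyl ring on that carbonyl carbon would lower the number further or raise it again. Whether the same swap moves the read-out as far on the core of compound 3 also stays unanswered.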